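The source may report more compounds than this note shows. Statements on the series, on what has been measured and on what is new or still open speak of the compounds shown alone.

Measured in a functional assay on DU-145 cells (Homo sapiens) for inhibition, read by trypan blue exclusion, with a stated time of 72 h; a higher number here means a weaker inhibitor, a lower number a stronger inhibitor:
- compound 1 `Cn1c(=O)c(S(=O)(=O)c2ccc(F)cc2F)cc2cnc(Nc3ccc4occc4c3)nc21`: 15000 nM
- compound 2 `Cn1c(=O)c(S(=O)(=O)c2ccc(F)cc2F)cc2cnc(Nc3ccc4cc[nH]c4c3)nc21`: 5000 nM

Of these two, compound 2 has the lower number, 5000 nM, and so stands as the stronger inhibitor. Compound 3 `Cn1c(=O)c(S(=O)(=O)c2ccc(F)cc2F)cc2cnc(Nc3ccc4c(c3)C(=O)C(=O)N4)nc21` has not been measured. Its difference from compound 2 is a group of 11 heavy atoms (8 carbon, 1 nitrogen, 2 oxygen; one five-membered non-aromatic ring with 1 hetero atom, one six-membered aromatic ring of carbon only) in place of a group of 9 heavy atoms (8 carbon, 1 nitrogen; one five-membered aromatic ring with 1 hetero atom, one six-membered aromatic ring of carbon only), on a nitrogen on an aromatic ring. The entering group keeps the six-membered aromatic ring of carbon only, but its five-membered ring is non-aromatic and it has 2 double bonds outside aromatic rings.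

Within the data shown here, only one measured step bears on this change, since it falls at the same place, on a nitrogen on an aromatic ring: a 3.0-fold lower number from compound 1 to compound 2 (0.48 log units; beyond the scatter). That step is modest, and it swapped one aromatic group for another, so it offers a guide to size but little to direction. Among the measured compounds shown here, the data hold no example of a non-aromatic five-membered ring here. For the measured compounds named here, with compound 2 the lower of only two values, a modest move to a higher number in this assay is the tentative expectation. The expected step is a 2.2-fold higher number from compound 2 to compound 3 (0.34 log units; beyond the scatter). For compound 3 the estimated value is 11000 nM, with an expected range of 3500 nM to 30000 nM.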

Compound 3, half-maximal inhibitory concentration: 75000 nM
Compound 3: the middle estimate sits 6.8-fold (0.83 log units) below what was measured, and the stated range ends below it.
By their numbers in this assay, from the lowest: compound 2; then compound 1; then compound 3.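

In this assay, the one non-aromatic five-membered ring in the series at this place, on a nitrogen on an aromatic ring, gives a 15-fold higher number from compound 2 to compound 3 (1.18 log units; beyond the scatter), a large step where the exchange of one aromatic group for another gave only a modest one, a 3.0-fold lower number from compound 1 to compound 2 (0.48 log units; beyond the scatter). The same entering group also stands worse than the 1-benzofuran-5-yl group, with a 5.0-fold higher number from compound 1 to compound 3 (0.70 log units; beyond the scatter), so compound 3 has the highest number of the three and this position shows a clear penalty for this change, not merely a shift within a flat range. No data at hand connect this penalty to any particular feature of the entering group.

The change alters the five-membered ring and adds 2 double bonds outside aromatic rings in a single step, so the compounds shown do not separate the contribution of the lost ring aromaticity from that of the two carbonyl groups. A non-aromatic five-membered ring with a single carbonyl, or one with no carbonyl at all, would divide these two contributions, and an amine or a carboxylic acid on the six-membered ring of the 1H-indol-6-yl group remains an open question at this place.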